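A few compounds are considered here, and "the series" means these few. Any claim that something is new, unique, unknown or untested is made for them only; others in the source may bear on it.

Measured compounds:
- compound 1, `CCN(Cc1ccccc1)C(=O)C1CCN(S(=O)(=O)c2c[nH]cn2)CC1`: in a functional assay on CHO cells for positive allosteric modulation of muscarinic acetylcholine receptor M5 (Homo sapiens), read by calcium flux (on this read-out higher numbers stand for larger maximal responses and lower numbers for smaller maximal responses), compound 1 gives "not determined" (no result reported)
- compound 2, `CCN(Cc1ccccc1)C(=O)C1CCN(S(=O)(=O)c2ccc3[nH]ncc3c2)CC1`: in this assay compound 2 gives 86%
- compound 3, `CCN(Cc1ccc(F)cc1)C(=O)C1CCN(S(=O)(=O)c2ccc3cn[nH]c3c2)CC1`: in this assay compound 3 gives 55%

Compound 3 stands lowest of the two numbers available. Its nearest neighbour is compound 2, whose maximal response is higher by a margin beyond the usual scatter of this assay; compound 2 and compound 3 differ in more than one place, so nothing can be read from that pair about any single change. Compound 1 carries no number and gives no anchor.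

The next compound, compound 4, `CCN(Cc1ccccc1Cl)C(=O)C1CCN(S(=O)(=O)c2ccc3cn[nH]c3c2)CC1`, differs from compound 3 in one place: 2-chlorophenyl in place of 4-fluorophenyl on a saturated chain carbon bound to an amide-type nitrogen. Among the compounds with values here, no measured pair shows this change, so its effect is unknown. The step is expected to be small and of uncertain direction: a number 5 percentage points higher from compound 3 to compound 4 (within the scatter) is expected to lie within or close to the scatter, with the outcome for compound 4 most likely in the same region as compound 3. The maximal response of compound 4 in this assay is estimated at 60%, with a range from 35% to 85%.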

Compound 4, largest response reached (reported as percent of maximum), in percent of the reference or control that the assay uses: 93%
Compound 4: middle estimate off by 33 percentage points, on the low side, outside the stated range (above it).
By their numbers in this assay, from the lowest: compound 3; then compounds 2 and 4 (each within the scatter of the next).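

In this assay, replacing 4-fluorophenyl with 2-chlorophenyl on a saturated chain carbon bound to an amide-type nitrogen gives a number 38 percentage points higher from compound 3 to compound 4 (beyond the scatter). Within the data shown here, this is the only step between compounds that differ in one place, and it shows that, with the rest of the molecule held constant, the group at this position can by itself shift the maximal response beyond the scatter, which the pair of compound 2 and compound 3 could not show as they differ in more than one place. No measurement is available that bears on what lies behind the step.

The change swaps fluorine for chlorine and the 4-substitution for the 2-substitution at once, so the compounds shown leave open which of the two carries the step, and 2-fluorophenyl and 4-chlorophenyl on the core of compound 4 would separate them. Also open, from the compounds shown here alone, is how far the position tolerates other groups, such as 2-methoxyphenyl, 2-methylphenyl or a plain phenyl on that same core.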